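Chain extension on the amino-oxolane core: compound 1 to compound 3

This account rests on a few compounds, and the source may have more. Where it says the series, first, only, none or still open, it means among the compounds named here.

Measured so far:
compound 1 `CCCCCCCNC[C@@H]1OC[C@H](N)[C@H]1O` — > 128000 nM
compound 2 `CCCCCCCCCNC[C@@H]1OC[C@H](N)[C@@H]1O` — 22100 nM

In a functional assay on A549 cells (Homo sapiens) for antiproliferative activity, read by MTT assay, with a stated time of 72 h (on this read-out higher numbers stand for weaker inhibition and lower numbers for stronger inhibition), compound 1 reaches only a limit, > 128000 nM, so no number is known for it. Its value sits at the limit of this assay (the limit of > 128000 nM in this assay, at which 1 of the 2 values shown sits). Compound 2 is carried on a core that differs from that of compound 1; in this assay compound 2 gives 22100 nM. Within the data shown here, no single-change step links the two, so their values are read side by side and nothing more is drawn from them.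

The unmeasured compound 3 `CCCCCCCCCCCCCCNC[C@@H]1OC[C@H](N)[C@H]1O` keeps the core of compound 1 and differs from it in one place: heptyl in place of hydrogen on a saturated chain carbon, seven bonds along the chain from an amine nitrogen. Because compound 1 stands at the limit (the limit of > 128000 nM in this assay, at which 1 of the 2 values shown sits), any numeric result for compound 3 would already mean a move toward stronger inhibition; the step from compound 1 to compound 3 in this assay is expected to be large, in that direction, well beyond the scatter. The estimate for compound 3 in this assay is 10000 nM, between 2000 nM and 60000 nM, which corresponds to an expected step of an at least 12-fold lower number from compound 1 to compound 3 (1.10 log units; beyond the scatter).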

Compound 3, half-maximal inhibitory concentration: 20000 nM
Compound 3: middle estimate off by 2.0-fold (0.30 log units), on the low side, within the range that was stated.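

Position note: in this assay, heptyl in place of hydrogen on a saturated chain carbon, seven bonds along the chain from an amine nitrogen, gives the first readable step on the core of compound 1: an at least 6.4-fold lower number from compound 1 to compound 3 (0.80 log units; beyond the scatter). This shows that the core of compound 1 can give a numeric result on this read-out when the chain is extended at this position, and that this all-carbon addition, with no ring, no hydrogen-bond donors or acceptors and no net charge, moves the number beyond the scatter. The step gives only a lower bound on the size of the change, because the value of compound 1 is a limit and not a number: the limit of > 128000 nM in this assay, at which 1 of the 3 values shown sits.

Compound 2 differs from compound 3 in more than one place, so the compounds shown do not separate the effect of the chain from that of the core, and the shape of the dependence on chain length remains open. Going by these compounds, whether a longer chain, or a chain ending in a carboxylic acid or an amine, would shift the number further at this position also remains open.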